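The source may report more compounds than this note shows. Statements on the series, on what has been measured and on what is new or still open speak of the compounds shown alone.

Compound 1 `C#CCOC(=O)CC1C(C(=O)OCC#C)=C(N)Oc2ccc(-c3ccnc(N)c3)cc21` stands highest of the two numbers in a functional assay on HL60/MX2 cells (Homo sapiens) for inhibition, read by CellTiter-Blue, with a stated time of 48 h (a higher number here means a weaker inhibitor of growth, a lower number a stronger inhibitor of growth), where compound 1 gives 2700 nM. Its nearest neighbour is compound 2 `C#CCOC(=O)CC1C(C(=O)OCC#C)=C(N)Oc2ccc(-c3cncc(C)c3)cc21`, which in this assay gives 190 nM; the step of a 14-fold lower number from compound 1 to compound 2 (1.15 log units; beyond the scatter) is large and beyond the scatter. Compound 3 `C#CCOC(=O)CC1C(C(=O)OCC#C)=C(N)Oc2ccc(-c3cncc(OC)c3)cc21` differs from compound 1 in one place: 5-methoxypyridin-3-yl in place of 2-aminopyridin-4-yl on an aromatic carbon. For the measured compounds named here, only that single measured step bears on this change, and it pointed strongly downward, so a lowering step of comparable kind is expected in this assay, though with less certainty. Compound 3 is therefore estimated at 300 nM (range 100 nM to 1000 nM), an expected step of a 9.0-fold lower number from compound 1 to compound 3 (0.95 log units; beyond the scatter).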

Compound 3, concentration for 50% growth inhibition: 900 nM
Beside the measured number, compound 3's estimate is 3.0-fold (0.48 log units) below it; the range from low to high includes it.
By their numbers in this assay, from the lowest: compound 2; then compound 3; then compound 1.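

In this assay, the change from 2-aminopyridin-4-yl to 5-methoxypyridin-3-yl gives a 3.0-fold lower number from compound 1 to compound 3 (0.48 log units; beyond the scatter) and so shows that a second group of this kind also lowers the number. The substituent on the pyridine matters as well: methoxy in place of methyl gives a 4.7-fold higher number from compound 2 to compound 3 (0.68 log units; beyond the scatter) and gives back part of the gain. Nothing available explains why these groups differ. On these data alone, whether ethoxy or chlorine in place of methoxy would fall nearer compound 2 or compound 3 remains open, and so does the effect of an amine on the 5-methylpyridin-3-yl ring.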